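Swapping an amino group for pyrrolidine on a shared core

This account rests on a few compounds, and the source may have more. Where it says the series, first, only, none or still open, it means among the compounds named here.

Compound 1 `O=C1C=C(NCc2ccccc2)C(=O)c2c1nc1n2[C@H]2OC[C@@H](O)[C@H]2OC1` gives 2670 nM
Compound 2 `O=C1C=C(Nc2cccc(Cl)c2)C(=O)c2c1nc1n2[C@H]2OC[C@@H](O)[C@H]2OC1` gives 1770 nM

Both numbers come from a functional assay on MGC-803 cells (Homo sapiens) for inhibition, read by sulforhodamine B assay; on this read-out higher numbers stand for weaker inhibition and lower numbers for stronger inhibition. Compound 2 stands level with compound 1: the whole gap is a 1.5-fold lower number from compound 1 to compound 2 (0.18 log units; within the scatter), and the two cannot be told apart.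

Compound 3 `O=C1C=C(N2CCCC2)C(=O)c2c1nc1n2[C@H]2OC[C@@H](O)[C@H]2OC1` keeps the shared core but changes one group, (pyrrolidin-1-yl in place of (3-chlorophenyl)amino on a double-bonded ring carbon). In words, this is pyrrolidin-1-yl in place of (3-chlorophenyl)amino on a double-bonded ring carbon.

Among the compounds with values here, only that one measured step bears on this change, with 3-chlorophenyl in place of benzyl on an amine nitrogen, and it stayed within the scatter. It is a thin guide. Within the data shown here, no measured compound carries pyrrolidin-1-yl yet, and a single step of that size points in no direction. No shift beyond the scatter is therefore expected, though with a wide margin of doubt. The expected step is a 1.4-fold higher number from compound 2 to compound 3 (0.13 log units; within the scatter). For compound 3 the estimated value is 2400 nM, with an expected range from 800 nM to 7500 nM.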

Compound 3, half-maximal inhibitory concentration: > 16000 nM
Compound 3 ended at the assay's limit; the forecaster's own chance of this, stated with the estimate: 5%; middle value at least 6.6-fold (0.82 log units) away from the limit.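

In this assay, the group on the double-bonded ring carbon turns out to matter: the earlier swap of benzyl for 3-chlorophenyl on the amine nitrogen stayed within the scatter, but replacing (3-chlorophenyl)amino with pyrrolidin-1-yl gives an at least 9.0-fold higher number from compound 2 to compound 3 (0.95 log units; beyond the scatter). Replacing benzylamino with pyrrolidin-1-yl tells the same story, with an at least 5.9-fold higher number from compound 1 to compound 3 (0.77 log units; beyond the scatter), so inhibition weakens clearly from either of the two earlier compounds. For compound 3, > 16000 nM is a limit of the assay and not a number, so both steps give only a smallest possible size: the limit of > 16000 nM in this assay, at which 1 of the 3 values shown sits.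

Compound 3 lacks both the amine hydrogen and the aromatic ring found in compound 1 and compound 2, and the compounds shown cannot tell which of these two differences goes with the weaker inhibition. Cyclopentylamino, which keeps the amine hydrogen without an aromatic ring, and methyl(phenyl)amino, which keeps the aromatic ring without the amine hydrogen, would pull the two apart.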